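The compounds below may be only part of what the source reports. "The series", "measured", "known", "first", "only" and "open" are said of these compounds alone.

Going by the values given here, in a functional assay on MDA-MB-468 cells (Homo sapiens) for antiproliferative activity (on this read-out higher numbers stand for weaker inhibition of growth and lower numbers for stronger inhibition of growth), compound 1, `COc1ccc(-c2nc3ccccc3s2)cc1OC`, gives 530 nM, the only exact number so far. Compound 2, `COc1ccc(-c2nc3cc(F)ccc3s2)cc1OC`, gives < 0.1 nM, which is a limit of the assay. Compound 3, `COc1ccc(-c2nc3c(F)cccc3s2)cc1OC`, differs from compound 1 by fluoro in place of hydrogen on an aromatic carbon, with the fluoro ortho to a fused ring and meta to a fused ring. Among the compounds with values here, the one measured step, an at least 5300-fold lower number from compound 1 to compound 2 (3.72 log units; beyond the scatter), is large and makes the same kind of exchange at a different carbon, so a smaller drop in the same direction is expected. The estimated step in this assay is a 27-fold lower number from compound 1 to compound 3 (1.42 log units; beyond the scatter). Compound 3 is expected at 20 nM, with an estimated range from 0.5 nM to 500 nM.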

Compound 3, concentration for 50% growth inhibition: 5 nM
Beside the measured number, compound 3's estimate is 4.0-fold (0.60 log units) above it, within the range that was stated.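

In this assay, going by these compounds alone, fluoro on this carbon, ortho to a fused ring and meta to a fused ring, gives a 110-fold lower number from compound 1 to compound 3 (2.03 log units; beyond the scatter), so a large drop is not tied to the one carbon changed in compound 2. Compound 3 also has an exact value, which gives this step a definite size. The gap between the two fluoro compounds cannot be sized because compound 2 sits at a limit of the assay: the limit of < 0.1 nM in this assay, at which 1 of the 3 values shown sits.

The compounds shown leave open what a chloro group, a methoxy group or an amine on this carbon would give in this assay.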